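A few compounds are considered here, and "the series" means these few. Any claim that something is new, unique, unknown or untested is made for them only; others in the source may bear on it.

Measured in a functional assay on DU-145 cells (Homo sapiens) for inhibition, read by trypan blue exclusion, with a stated time of 96 h; a higher number here means a weaker inhibitor of growth, a lower number a stronger inhibitor of growth:
- compound 1 `COc1cc(/C=C(/Sc2ccc(Br)cc2)C(=O)c2ccc(Br)cc2)ccc1O`: 1000 nM
- compound 2 `O=C(/C(=C\c1ccc([N+](=O)[O-])c(O)c1)SCc1ccc(Br)cc1)c1ccc([N+](=O)[O-])cc1`: 1000 nM
- compound 3 `Cc1ccc(S(=O)(=O)/C(=C/c2ccc(C)s2)C(=O)c2ccc(Br)cc2)cc1`: 25000 nM

Compound 1 gives 1000 nM, level with compound 2 at 1000 nM, and the two share the lowest number of the three. Compound 3 gives 25000 nM, a higher number than either of them, and that gap lies beyond the scatter.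

The next compound to be tested, compound 4 `COc1ccc(/C=C(/Sc2ccc(Br)cc2)C(=O)c2ccc(Br)cc2)cc1`, keeps the core of compound 1 but carries 4-methoxyphenyl in place of 4-hydroxy-3-methoxyphenyl on a double-bonded chain carbon bound to a double-bonded chain carbon. Among the measured compounds shown here, no two measured compounds differ in a single place, so the data offer no direct precedent for this change, and the expectation starts from compound 1 at 1000 nM. In this assay a small rise in the number is expected, one that probably stays within the scatter, and the estimated step is a 1.5-fold higher number from compound 1 to compound 4 (0.18 log units; within the scatter). The estimate for compound 4 is 1500 nM. The expected range for compound 4 runs from 400 nM to 6000 nM.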

Compound 4, concentration for 50% growth inhibition: 25000 nM
Estimate against measurement, compound 4: 17-fold (1.22 log units) below; the measured number lies above the stated range.
By their numbers in this assay, from the lowest: compounds 1 and 2 (each within the scatter of the next); then compounds 3 and 4 (each within the scatter of the next).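

In this assay, among the compounds shown here, the swap of 4-hydroxy-3-methoxyphenyl for 4-methoxyphenyl on a double-bonded chain carbon bound to a double-bonded chain carbon is the only single-place comparison available (a 25-fold higher number from compound 1 to compound 4 (1.40 log units; beyond the scatter)), and it is a large step beyond the scatter. It shows that this position is not indifferent to the group it carries: the loss of one oxygen and the one hydrogen-bond donor, with the rest of the core of compound 1 unchanged, goes with a much weaker inhibitor of growth. Nothing measured here accounts for the size of this step.

The compounds shown leave open whether the donor or the oxygen count matters more. They also leave open whether an amine or a carboxylic acid on this aromatic ring would hold the number of compound 1.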